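From fluoro to trifluoromethoxy on a weak compound

The source may report more compounds than this note shows. Statements on the series, on what has been measured and on what is new or still open speak of the compounds shown alone.

Compound 1 `Oc1ccc(-c2cc(-c3ccccc3F)cc(-c3ccccc3O)n2)cc1`: > 50000 nM
Compound 2 `Oc1ccc(-c2cc(-c3ccccc3F)cc(-c3ccc(O)cc3)n2)cc1`: 8180 nM

In a functional assay on HCT-15 cells (Homo sapiens) for inhibition (a lower number here means a stronger inhibitor, a higher number a weaker inhibitor), compound 1 gives only a limit, > 50000 nM, and no number. Compound 3 `Oc1ccc(-c2cc(-c3ccccc3OC(F)(F)F)cc(-c3ccccc3O)n2)cc1` carries trifluoromethoxy in place of fluoro on an aromatic carbon. Among the compounds with values here, the one measured step, an at least 6.1-fold lower number from compound 1 to compound 2 (0.78 log units; beyond the scatter), puts 4-hydroxyphenyl in place of 2-hydroxyphenyl, so it bears on this change only indirectly, showing that the shared core can reach a measurable value. At most a modest step to a lower number is therefore expected in this assay, and another limit remains quite possible. The estimated step is an at least 1.6-fold lower number from compound 1 to compound 3 (0.22 log units; that floor lies within the scatter). Compound 3 is expected at 30000 nM, within an estimated range of 7000 nM to 60000 nM.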

Compound 3, half-maximal inhibitory concentration: 9820 nM
Compound 3: middle estimate off by 3.1-fold (0.49 log units), on the high side, within the range that was stated.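

Trifluoromethoxy in place of fluoro, on an aromatic carbon ortho to a large group, gives an at least 5.0-fold lower number from compound 1 to compound 3 (0.70 log units; beyond the scatter) in this assay. Within the data shown here, a compound that keeps 2-hydroxyphenyl can therefore reach a measured value, which the earlier compounds did not show. The full size of this step cannot be read because compound 1 gives only a limit: the limit of > 50000 nM in this assay, at which 1 of the 3 values shown sits.

The compounds shown leave open how a methoxy group or an amine at this place would compare with trifluoromethoxy. They also leave open how trifluoromethoxy behaves alongside 4-hydroxyphenyl.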